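The source may hold more compounds than are shown below. What is called first, only, known or untested is meant among the compounds shown, and "the series" means these compounds.

Working notes on the series

Three compounds have numbers in an assay on isolated protein for inhibition of tyrosine-protein kinase receptor UFO (Homo sapiens), with a stated time of 1.5 h; on this read-out lower numbers stand for stronger inhibition and higher numbers for weaker inhibition. Compound 1, `Cn1cc(-c2n[nH]c3ccc(N[C@@H]4CCNC4)cc23)cn1`, gives 37000 nM, the smallest of the three numbers, but neither neighbour is separated from it by more than the usual scatter. Compound 2, `CC(C)Nc1ccc2c(-c3cnn(C)c3)n[nH]c2c1`, gives 46600 nM in this assay. Compound 3, `Nc1ccc(Br)c2ccncc12`, a compound of a different core, gives 57000 nM in this assay. All three numbers therefore sit in one band of weak inhibition, and no ordering among them can be read from these data.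

Compound 4, `Cn1cc(-c2n[nH]c3ccc(NC4CCNC4)cc23)cn1`, is next in line. Among the measured compounds shown here, its difference from compound 1 is the two compounds have the same atoms and bonds; at least one stereo element is drawn with a configuration in one of them and without one in the other: 1 of 1 stereo elements differ; a stereocentre at a saturated ring carbon is drawn R in compound 1 and without a configuration in compound 4; the two compounds have the same atoms and bonds, and the only change is that the stereocentre at a saturated ring carbon is drawn R in compound 1 and without a configuration in compound 4. For the measured compounds named here, no step between measured compounds of this kind is available in this assay. A change that removes only the drawn configuration is expected to shift the number, if at all, towards a somewhat higher value, and not beyond the scatter. For compound 4 the expected value in this assay is 48000 nM, with a range from 22000 nM to 105000 nM. This estimate means an expected step of a 1.3-fold higher number from compound 1 to compound 4 (0.11 log units; within the scatter).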

Compound 4, half-maximal inhibitory concentration: 132000 nM
Compound 4: middle estimate off by 2.8-fold (0.44 log units), on the low side, outside the stated range (above it).
By their numbers in this assay, from the lowest: compounds 1, 2 and 3 (each within the scatter of the next); then compound 4.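

In this assay, among the compounds shown here, a 3.6-fold higher number from compound 1 to compound 4 (0.55 log units; beyond the scatter) is the first step to lie beyond the scatter, and it comes without any change of atoms or bonds. The earlier compounds shown here gave one undivided band, whereas this pair shows that the number at this saturated ring carbon can move with the way the stereocentre is drawn, even though the step is modest and both compounds remain weak inhibitors. The only structural ground the pair offers for the step is this: the fact that one of compounds 1 and 4 is drawn with a defined configuration and the other without, at the place where they differ

The compounds shown leave open what a compound drawn S at this carbon would give, and so whether the undefined drawing of compound 4 conceals a difference between the two configurations. They also leave open whether an open-chain amine or a carboxylic acid at this place would keep the number of compound 1.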